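Chain-end variation on the shared quinone core

A few compounds are considered here, and "the series" means these few. Any claim that something is new, unique, unknown or untested is made for them only; others in the source may bear on it.

Among the measured compounds shown here, compound 2 `CCCCCCCCCCCCCCCC1=C(C)C(=O)C(OC)=C(OC)C1=O` stands highest of the two numbers measured so far in a functional assay on CCRF-CEM cells (Homo sapiens), read by flow cytometry, using a membrane potential dye, with stated times of 16 h and 120 min, tested at 1 uM (a lower number here means a weaker effect, a higher number a stronger effect of the compound at the concentration tested), where compound 2 gives 92%. For the measured compounds named here, its nearest measured neighbour is compound 1 `COC1=C(OC)C(=O)C(CCCCCCCCCCN=[N+]=[N-])=C(C)C1=O`, which in this assay gives 65%; the single measured step, a number 27 percentage points higher from compound 1 to compound 2 (beyond the scatter), is a change at one place on the saturated chain, and it sets the only scale available for what a change out on the chain has done. Compound 3 `COC1=C(OC)C(=O)C(CCCCCCCCC(C)(C)C)=C(C)C1=O` is the next compound and differs from compound 2 as follows: tert-butyl in place of heptyl on a saturated chain carbon, eight bonds along the chain from a double-bonded ring carbon. Going by the values given here, no measured step exchanges heptyl for tert-butyl, so the one measured step is only a loose guide: it shows that a change on the chain moved the read-out beyond the scatter, with the larger group giving the higher number. Because compound 2 gives 92% and that is the higher of the two numbers, compound 3 is expected to sit somewhat under it, and a step of a number 12 percentage points lower from compound 2 to compound 3 (beyond the scatter) is estimated. For compound 3 the expected value in this assay is 80%, in the range 60% to 96%.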

Compound 3, a percentage reported as activity, at one concentration (the size of the read-out at that concentration, not a potency): 85%
Compound 3: middle estimate off by 5 percentage points, on the low side; the measured number falls inside the stated range.
By their numbers in this assay, from the lowest: compound 1; then compounds 3 and 2 (each within the scatter of the next).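

In this assay, tert-butyl in place of heptyl, on a saturated chain carbon eight bonds along the chain from a double-bonded ring carbon, gives a number 7 percentage points lower from compound 2 to compound 3 (within the scatter), so at this one concentration the read-out does not separate the branched chain end of compound 3 from the straight chain of compound 2. Tert-butyl in place of 2-azidoethyl at the same place gives a number 20 percentage points higher from compound 1 to compound 3 (beyond the scatter), which adds a second step from the azido compound, alongside a number 27 percentage points higher from compound 1 to compound 2 (beyond the scatter); among these three compounds, the azido chain end of compound 1 is the one that stands apart, while the two all-carbon chain ends do not separate from each other. Nothing measured on these compounds offers an explanation for either step.

From the compounds shown here alone, the series holds only one chain end bearing a heteroatom, so it remains open whether a hydroxyl, an amine or a carboxylic acid at the chain end would also read apart from the all-carbon ends. Also open, going by these compounds, is whether a longer chain ending in tert-butyl would keep the read-out, and whether compound 2 and compound 3 would stay together at other concentrations.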